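Adding a Methyl: From Isopropyl to Tert-Butyl

This account rests on a few compounds, and the source may have more. Where it says the series, first, only, none or still open, it means among the compounds named here.

Compound 1, `Cc1ccc(C(=O)NC(=N)Nc2ccc(OCc3ccccc3)cc2)cc1`: 10100 nM
Compound 2, `Cc1ccc(C(=O)NC(=N)Nc2ccc(C(C)C)cc2)cc1`: 1950 nM

Both measured compounds share the same core and differ only in the group attached to one aromatic carbon. In an assay on CHO cells for inhibition of sodium channel protein type 2 subunit alpha (Homo sapiens) (on this read-out lower numbers stand for stronger inhibition and higher numbers for weaker inhibition), compound 1 gives 10100 nM, while compound 2 gives 1950 nM. Among the measured compounds shown here, of the two numbers, compound 2 has the lowest: the single measured step, isopropyl in place of benzyloxy on an aromatic carbon, gave a 5.2-fold lower number from compound 1 to compound 2 (0.71 log units; beyond the scatter).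

Compound 3, `Cc1ccc(C(=O)NC(=N)Nc2ccc(C(C)(C)C)cc2)cc1`, has not yet been measured. Its change from compound 2 is methyl in place of hydrogen on a saturated chain carbon bound to an aromatic carbon and two saturated chain carbons. For the measured compounds named here, the one measured step swapped a whole benzyloxy group for an isopropyl, a far bigger change than adding a single methyl, so it offers no direct guide to this smaller step. With nothing in the data pointing to a large effect either way, the expectation for compound 3 in this assay is a step of a 1.3-fold lower number from compound 2 to compound 3 (0.11 log units; within the scatter), small and likely within the scatter. Compound 3 is therefore estimated at 1500 nM, with a range from 500 nM to 5000 nM.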

Compound 3, half-maximal inhibitory concentration: > 24000 nM
Compound 3: only a limit was reported (the forecaster's own chance of this, stated with the estimate: 3%); middle value at least 16-fold (1.20 log units) from the limit.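

On this aromatic carbon, a single added methyl, the change from isopropyl to tert-butyl, matters far more than its small size might suggest: this assay shows an at least 12-fold higher number from compound 2 to compound 3 (1.09 log units; beyond the scatter). Swapping benzyloxy for tert-butyl also gives an at least 2.3-fold higher number from compound 1 to compound 3 (0.37 log units; beyond the scatter), so the group with more atoms, benzyloxy, is not the one with the weakest reading, and these three compounds show no steady rise in the number as the group on this carbon grows. The reading for compound 3 is a limit and not a measured number, so both steps give only a minimum size: the limit of > 24000 nM in this assay, at which 1 of the 3 values shown sits.

How far the true value of compound 3 lies past that limit stays unknown, and the compounds shown give no reason why the extra methyl has such a large effect. They also leave open how an ethyl or a cyclopropyl group on the same aromatic carbon would read, which would show whether the sharp change sets in only at tert-butyl or appears with other small groups as well.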